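Exchanges on the ring nitrogen of a shared core

This account rests on a few compounds, and the source may have more. Where it says the series, first, only, none or still open, it means among the compounds named here.

compound 1 `Nc1scc(CN2CCN(c3ccc([N+](=O)[O-])cc3)CC2)c1C(=O)c1ccc(Cl)cc1`: 1%
compound 2 `Nc1scc(CN2CCN(c3ccccc3C(F)(F)F)CC2)c1C(=O)c1ccc(Cl)cc1`: 0%
compound 3 `Nc1scc(CN2CCN(c3ccc(Cl)c(C(F)(F)F)c3)CC2)c1C(=O)c1ccc(Cl)cc1`: 0%

In an assay on CHO cells for displacement of a labelled ligand from adenosine receptor A1 (Homo sapiens), read by scintillation counting, with a stated time of 120 min, tested at 10 uM (a higher number here means more inhibition at the concentration tested (going by the name of the read-out), a lower number less inhibition), compound 1 gives 1%, the highest of the three numbers, though the steps of a number 1 percentage points lower from compound 1 to compound 2 (within the scatter) and a number 1 percentage points lower from compound 1 to compound 3 (within the scatter) both lie within the scatter, so no ordering among the three can be read from them. Compound 4 `Nc1scc(CN2CCN(c3ccc(F)c(Cl)c3)CC2)c1C(=O)c1ccc(Cl)cc1` is not yet measured. It differs from compound 1 as follows: 3-chloro-4-fluorophenyl in place of 4-nitrophenyl on an amine nitrogen in a ring. Among the compounds with values here, the steps that bear on this exchange are the two earlier replacements of the same group on the same ring nitrogen, a number 1 percentage points lower from compound 1 to compound 2 (within the scatter) and a number 1 percentage points lower from compound 1 to compound 3 (within the scatter), together with no change at the digits printed from compound 2 to compound 3 (within the scatter); none of them moves beyond the scatter. No step beyond the scatter is therefore expected in this assay for compound 4. Compound 4 is expected near 1%, with a range from -8% to 10%. The expected step is no change at the digits printed from compound 1 to compound 4 (within the scatter).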

Compound 4, a percentage reported as inhibition, at one concentration (the size of the read-out at that concentration, not a potency): 0%
Compound 4: middle estimate off by 1 percentage points, on the high side, within the range that was stated.
By their numbers in this assay, from the lowest: compounds 2, 3, 4 and 1 (each within the scatter of the next).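

Exchanging 4-nitrophenyl, with its two hydrogen-bond acceptors, for 3-chloro-4-fluorophenyl, with none, gives no readable shift in this assay: a number 1 percentage points lower from compound 1 to compound 4 (within the scatter). An aryl group carrying only halogens, with no trifluoromethyl, also reads the same as the trifluoromethyl-bearing groups, with no change at the digits printed from compound 3 to compound 4 (within the scatter) and no change at the digits printed from compound 2 to compound 4 (within the scatter) on the same ring nitrogen. No evidence bears on this flat result.

From the compounds shown here alone, whether any group on this nitrogen can raise the number remains open. A carboxylic acid or an amine on a longer chain there might behave differently, and the compounds shown do not settle it.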